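Swapping 2-hydroxyethoxy for (2-hydroxyethyl)amino on a carbonyl carbon

The compounds below may be only part of what the source reports. "The series", "measured", "known", "first", "only" and "open" are said of these compounds alone.

In a physicochemical assay for lipophilicity, read by HPLC, measured as chromatographic lipophilicity (a higher number here means a more lipophilic compound, a lower number a more polar compound), compound 1 (`CCC/N=C1\S/C(=C\c2ccc(C(=O)O)cc2)C(=O)N1c1ccccc1C`) gives 1. Compound 2 (`CCC/N=C1\S/C(=C\c2ccc(C(=O)OC)cc2)C(=O)N1c1ccccc1C`) gives > 4.4, which is a limit of the assay and not a number. Compound 3 (`CCC/N=C1\S/C(=C\c2ccc(C(=O)OCCO)cc2)C(=O)N1c1ccccc1C`) gives 3.4, the higher of the two true numbers in the set, and the gap is large: a number 2.40 log units higher from compound 1 to compound 3 (beyond the scatter). Methyl in place of the same hydrogen gives a number at least 3.40 log units higher from compound 1 to compound 2 (beyond the scatter), also a large step. Compound 4 (`CCC/N=C1\S/C(=C\c2ccc(C(=O)NCCO)cc2)C(=O)N1c1ccccc1C`) carries (2-hydroxyethyl)amino in place of 2-hydroxyethoxy on a carbonyl carbon, and the core is unchanged: (2-hydroxyethyl)amino in place of 2-hydroxyethoxy on a carbonyl carbon. Among the measured compounds shown here, no measured step makes this exchange, so the evidence is indirect. The three steps show that this assay responds strongly to changes at this end of the molecule. The closest guide is a number at least 1.00 log units lower from compound 2 to compound 3 (beyond the scatter), a step of at least modest size downward, and it suggests that a change in the hydrogen-bond count here can lower the number. The exchange keeps the chain length, so a modest fall is expected rather than a large one. The expected change is a number 0.70 log units lower from compound 3 to compound 4 (beyond the scatter). For compound 4 the estimated value is 2.7, with an expected range from 2.2 to 3.2.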

Compound 4, distribution coefficient: 2.3
Compound 4: middle estimate off by 0.40 log units, on the high side; the range from low to high includes it.
By their numbers in this assay, from the lowest: compound 1; then compound 4; then compound 3. At a limit, above all of these: compound 2.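

In this assay, the exchange on the carbonyl carbon is a large step on its own: (2-hydroxyethyl)amino in place of 2-hydroxyethoxy gives a number 1.10 log units lower from compound 3 to compound 4 (beyond the scatter) even though the heavy-atom count stays the same and only the linking atom and the donor and acceptor counts differ. The new group still does not return the number to that of the hydroxy compound, since (2-hydroxyethyl)amino in place of hydroxy gives a number 1.30 log units higher from compound 1 to compound 4 (beyond the scatter). By their numbers, compound 4 therefore stands between compound 1 and compound 3. Compound 2 stands at a limit and not a number, so the exchange of methoxy for (2-hydroxyethyl)amino, a number at least 2.10 log units lower from compound 2 to compound 4 (beyond the scatter), gives only a minimum size for that step: the limit of > 4.4 in this assay, at which 1 of the 4 values shown sits.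

The compounds shown leave open whether the same fall would appear with a longer chain on the nitrogen, or with an amine in place of the terminal hydroxy group. They also leave open whether methylamino on the carbonyl carbon would differ from methoxy by a similar step, and whether the exchange would behave the same way on a different core.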